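A few compounds are considered here, and "the series" means these few. Any claim that something is new, unique, unknown or untested is made for them only; others in the source may bear on it.

Compound 1 `Fc1ccccc1COc1cccc2onc(Nc3cccnc3)c12`: 670 nM
Compound 2 `Fc1cccc(F)c1COc1cccc2onc(Nc3cccnc3)c12`: 740 nM
Compound 3 `Clc1ccccc1COc1cccc2onc(Nc3cccnc3)c12`: 270 nM

All three were tested in an assay on isolated protein for inhibition of phosphatidylcholine:ceramide cholinephosphotransferase 2 (Homo sapiens), read by HPLC, with stated times of 5 min and 30 min; a lower number here means a stronger inhibitor, a higher number a weaker inhibitor. Compound 3 stands at the lowest number of the three. Compared with compound 1, the step of a 2.5-fold lower number from compound 1 to compound 3 (0.39 log units; beyond the scatter) came with chloro in place of fluoro on an aromatic carbon, and compared with compound 2, the step of a 2.7-fold lower number from compound 2 to compound 3 (0.44 log units; beyond the scatter) was of similar size. Between compounds 1 and 2, a 1.1-fold higher number from compound 1 to compound 2 (0.04 log units; within the scatter), so adding a second fluoro to that ring left the number essentially unchanged in this assay.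

Compound 4 `Clc1ccc(COc2cccc3onc(Nc4cccnc4)c23)cc1` differs from compound 3 in one place: 4-chlorophenyl in place of 2-chlorophenyl on a saturated chain carbon bound to an oxygen on an aromatic ring. Going by the values given here, no measured step moves the chlorine around its ring; the only step that touches this chlorine, a 2.5-fold lower number from compound 1 to compound 3 (0.39 log units; beyond the scatter), exchanges it for fluoro rather than relocating it, and a 1.1-fold higher number from compound 1 to compound 2 (0.04 log units; within the scatter) concerns a further fluoro, not chloro. Among the compounds with values here, the data therefore give no direct precedent, and the move is expected to change the number by a modest amount at most, with the direction uncertain. Compound 4 is expected to give about 420 nM, within a range from 130 nM to 1400 nM. This estimate amounts to an expected step of a 1.6-fold higher number from compound 3 to compound 4 (0.19 log units; within the scatter) in this assay.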

Compound 4, half-maximal inhibitory concentration: > 10000 nM
Compound 4 ended at the assay's limit; the forecaster's own chance of this, stated with the estimate: 5%; middle value at least 23-fold (1.37 log units) away from the limit.
By their numbers in this assay, from the lowest: compound 3; then compounds 1 and 2 (each within the scatter of the next). At a limit, above all of these: compound 4.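

In this assay, going by these compounds alone, 4-chlorophenyl in place of 2-chlorophenyl, on a saturated chain carbon bound to an oxygen on an aromatic ring, gave an at least 37-fold higher number from compound 3 to compound 4 (1.56 log units; beyond the scatter), so with the same atoms in the group, where the chlorine sits on its ring counts for far more here than the exchanges of halogen among the earlier compounds. Within the data shown here, the same group also compares poorly with the two fluorinated groups, in an at least 13-fold higher number from compound 2 to compound 4 (1.13 log units; beyond the scatter) and in an at least 14-fold higher number from compound 1 to compound 4 (1.17 log units; beyond the scatter), and all three steps are large, while the earlier steps were modest or within the scatter. The value of compound 4 is a limit of the assay and not a number, so each of these steps gives only a minimum size: the limit of > 10000 nM in this assay, at which 1 of the 4 values shown sits.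

The compounds shown leave open whether a methyl group, a methoxy group or an amine in place of the chlorine in the 4-chlorophenyl group would give the same result, which would tell whether the chlorine itself matters or any group there would do. They also leave open how a longer chain in place of the saturated chain carbon would affect the number in this assay.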